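Permeability of two quinoline amines after swapping the aryl group

The source may hold more compounds than are shown below. What is called first, only, known or untested is meant among the compounds shown, and "the series" means these compounds.

Measured in an ADME assay for permeability, using PAMPA, with a stated time of 30 min, at pH 7.4; on this read-out lower numbers stand for lower permeability and higher numbers for higher permeability:
compound 1, `COc1ccc(-c2ccc3c(NCCCNCc4cccc(OC)c4O)ccnc3c2)cc1`, gives 237 10^-6 cm/s;
compound 2, `COc1cccc(CNCCCNc2ccnc3cc(Cc4cccc(C(F)(F)F)c4)ccc23)c1O`, gives 23 10^-6 cm/s;
compound 3, `COc1ccc(-c2ccc3c(NCCCNCc4cc(F)ccc4OC)ccnc3c2)cc1`, gives 237 10^-6 cm/s.

The change from compound 1 to compound 2 is 3-(trifluoromethyl)benzyl in place of 4-methoxyphenyl on an aromatic carbon, and it made a 10-fold lower number from compound 1 to compound 2 (1.01 log units; beyond the scatter). Compound 4, `COc1ccc(F)cc1CNCCCNc1ccnc2cc(Cc3cccc(C(F)(F)F)c3)ccc12`, has not yet been measured; it differs from compound 3 by 3-(trifluoromethyl)benzyl in place of 4-methoxyphenyl on an aromatic carbon, at the same place, so this is the same change, seen twice in all among these compounds. The two cores differ by 5-fluoro-2-methoxyphenyl in place of 2-hydroxy-3-methoxyphenyl on a saturated chain carbon bound to an amine nitrogen, which made no change at the digits printed from compound 1 to compound 3 (within the scatter). Going by the values given here, for compound 4 in this assay a step of a 9.9-fold lower number from compound 3 to compound 4 (0.99 log units; beyond the scatter) from compound 3 is expected, resting on the single earlier step of a 10-fold lower number from compound 1 to compound 2 (1.01 log units; beyond the scatter). Compound 4 is therefore estimated at 24 10^-6 cm/s, between 10 10^-6 cm/s and 60 10^-6 cm/s.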

Compound 4, apparent permeability: 23 10^-6 cm/s
For compound 4 the middle estimate is 1.0-fold (0.02 log units) above the measured one; measured number inside the range.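

In this assay, 3-(trifluoromethyl)benzyl in place of 4-methoxyphenyl gave a 10-fold lower number from compound 3 to compound 4 (1.01 log units; beyond the scatter), so the change carried from the core of compound 1 to the core of compound 3 with its size intact: the same change on two cores in this assay, a 10-fold lower number (1.01 log units; beyond the scatter) from compound 1 to compound 2 and a 10-fold lower number (1.01 log units; beyond the scatter) from compound 3 to compound 4, 1.0-fold (0.00 log units) apart, within the scatter of two such steps. Likewise, 5-fluoro-2-methoxyphenyl in place of 2-hydroxy-3-methoxyphenyl gave no change at the digits printed from compound 2 to compound 4 (within the scatter), matching the earlier step: the same change on two cores in this assay, no change at the digits printed (within the scatter) from compound 1 to compound 3 and no change at the digits printed (within the scatter) from compound 2 to compound 4, 1.0-fold (0.00 log units) apart, within the scatter of two such steps. The two changes therefore behaved as separate, transferable steps across these four compounds, but this rests on one pair of cores in one assay and does not show that the steps would hold on other cores or why the number drops.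

Left open is whether a similar drop follows when a carboxylic acid or a morpholine takes the place of 3-(trifluoromethyl)benzyl. The compounds shown also leave open whether the steps hold with a longer chain between the two amine nitrogens.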